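Methylating the Phenolic Hydroxy in a Biaryl Acid Series

The source may hold more compounds than are shown below. What is called first, only, known or untested is meant among the compounds shown, and "the series" means these compounds.

Compound 1 `Cc1c(OCc2cccc(-c3cccc(C(=O)O)c3)c2)cc2c(c1C)C(=O)C(C1CCCC1)C2`: 69 nM
Compound 2 `Cc1c(OCc2cccc(-c3ccc(O)c(C(=O)O)c3)c2)cc2c(c1C)C(=O)C(C1CCCC1)C2`: 62 nM

In an assay on HEK293 cells for positive allosteric modulation of metabotropic glutamate receptor 2 (Rattus norvegicus), read by thallium flux, in the presence of a further agent that is not named here (on this read-out higher numbers stand for an effect only at larger amounts of compound and lower numbers for an effect already at smaller amounts), compound 2 gives 62 nM. Of the two numbers shown, that of compound 2 is the smaller, but a 1.1-fold lower number from compound 1 to compound 2 (0.05 log units; within the scatter) is within the scatter, so the two compounds are not told apart. Compound 3 `COc1ccc(-c2cccc(COc3cc4c(c(C)c3C)C(=O)C(C3CCCC3)C4)c2)cc1C(=O)O` differs from compound 2 by methyl in place of hydrogen on an oxygen on an aromatic ring, that is hydroxy to methoxy. For the measured compounds named here, no measured step alters a group on an oxygen; the single step recorded, hydrogen to hydroxy on an aromatic carbon, stayed within the scatter. A step of a 1.1-fold higher number from compound 2 to compound 3 (0.05 log units; within the scatter) is therefore expected, with no direction claimed beyond the scatter. Compound 3 is estimated at 70 nM, between 25 nM and 200 nM.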

Compound 3, half-maximal effective concentration: 84.3 nM
Beside the measured number, compound 3's estimate is 1.2-fold (0.08 log units) below it; measured number inside the range.
By their numbers in this assay, from the lowest: compounds 2, 1 and 3 (each within the scatter of the next).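

Methyl in place of hydrogen on an oxygen on an aromatic ring is the only measured change of this kind, and in this assay it stays within the scatter (a 1.4-fold higher number from compound 2 to compound 3 (0.13 log units; within the scatter)). Compared with compound 1, which carries hydrogen on the aromatic carbon, the methoxy also stays within the scatter (a 1.2-fold higher number from compound 1 to compound 3 (0.09 log units; within the scatter)). Hydrogen, hydroxy and methoxy at this place are therefore not told apart, and no evidence on why accompanies the result.

The compounds shown leave open whether an ethoxy or a benzyloxy group here would also leave the number within the scatter. They also do not show how an amine in place of the hydroxy would read.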